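A few compounds are considered here, and "the series" means these few. Any claim that something is new, unique, unknown or untested is made for them only; others in the source may bear on it.

Three compounds have numbers so far in a functional assay on HT-29 cells (Homo sapiens) for cytotoxicity, read by MTT assay, with a stated time of 6 days; a lower number here means that less compound is needed, a higher number that more compound is needed for the effect
- compound 1 `O=c1cc(-c2ccc([N+](=O)[O-])cc2)oc2c(O)c(O)ccc12` gives 3.46 ug/mL
- compound 2 `COc1cc(-c2cc(=O)c3cc(O)ccc3o2)cc(OC)c1OC` gives 7.85 ug/mL
- compound 3 `COc1cc(-c2cc(=O)c3cc(O)ccc3o2)cc(OC)c1O[Si](C)(C)C(C)(C)C` gives 2.63 ug/mL

Compound 3 stands within the usual scatter of compound 1 and under compound 2 by more than the scatter. The next compound, compound 4 `COc1cc(-c2cc(=O)c3cc(O)ccc3o2)cc(OC)c1O` differs from compound 3 by a hydrogen atom in place of a group of 7 heavy atoms (6 carbon, 1 silicon; no ring), on an oxygen on an aromatic ring and in nothing else. Among the measured compounds shown here, one measured step bears on this change: a 3.0-fold lower number from compound 2 to compound 3 (0.47 log units; beyond the scatter) is a modest step that brought the same group onto the same oxygen in place of one carbon atom. For the measured compounds named here, removing the group is not the exact reverse of that step, since hydrogen enters here and not carbon, and no measured pair shows hydrogen on this oxygen. A move to a higher number in this assay is therefore expected, of similar or smaller size. The expected change is a 2.3-fold higher number from compound 3 to compound 4 (0.36 log units; beyond the scatter) by this estimate. For compound 4 the estimated value is 6 ug/mL within an expected range from 2.5 ug/mL to 14 ug/mL in this assay.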

Compound 4, concentration for half-maximal effect: > 25 ug/mL
Compound 4 gave a limit, no number; the forecaster's own chance of this, stated with the estimate: 2%; at least 4.1-fold (0.61 log units) between middle value and limit.
By their numbers in this assay, from the lowest: compounds 3 and 1 (each within the scatter of the next); then compound 2. At a limit, above all of these: compound 4.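

Hydrogen on this oxygen gives an at least 9.5-fold higher number from compound 3 to compound 4 (0.97 log units; beyond the scatter), and hydrogen in place of methyl gives an at least 3.1-fold higher number from compound 2 to compound 4 (0.50 log units; beyond the scatter), so in this assay both compounds with a group on this oxygen stand under the compound with hydrogen there. Compound 4 gave a limit and not a number: the limit of > 25 ug/mL in this assay, at which 1 of the 4 values shown sits. Among the compounds shown here, the earlier compounds compared only two groups on this oxygen, methyl and the group of 7 heavy atoms, whereas these steps show that having no such group at all costs more than the scatter, with only the lower end of that cost known.

The compounds shown leave open how far past its limit compound 4 lies. They also leave open where an ethyl group, a longer chain or an acetyl group on the same oxygen would fall relative to compound 2 and compound 3.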